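Extending the Sulfonamide Substituent from Methyl to Ethyl

The source may report more compounds than this note shows. Statements on the series, on what has been measured and on what is new or still open speak of the compounds shown alone.

Compound 2 `CN(C1CCCC1)S(=O)(=O)c1ccc(NC(=O)NCc2ccncc2)cc1` stands at the low end of the two numbers recorded in an assay on isolated protein for activation of Nicotinamide phosphoribosyltransferase (Homo sapiens) (a lower number here means that less compound is needed, a higher number that more compound is needed for the effect), giving 123 nM. Going by the values given here, its only neighbour, compound 1 `CNS(=O)(=O)c1ccc(NC(=O)NCc2ccncc2)cc1`, gives 3230 nM in this assay, and the step of a 26-fold lower number from compound 1 to compound 2 (1.42 log units; beyond the scatter) shows that growing the group on the sulfonamide nitrogen moved the number far beyond the scatter. Compound 3 `CCN(C1CCCC1)S(=O)(=O)c1ccc(NC(=O)NCc2ccncc2)cc1` differs from compound 2 by methyl in place of hydrogen on a saturated chain carbon bound to a sulfonamide nitrogen. Among the compounds with values here, no measured pair shows exactly this lengthening of a chain; the step from compound 1 to compound 2 concerns the same nitrogen but adds a whole ring rather than one carbon, so it is only a loose guide. A small step, if any, is therefore expected, with direction uncertain and most likely within the scatter. Compound 3 is estimated to give 100 nM in this assay, in a range from 35 nM to 300 nM, which means an expected step of a 1.2-fold lower number from compound 2 to compound 3 (0.09 log units; within the scatter).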

Compound 3, half-maximal effective concentration: 60 nM
Compound 3: the middle estimate sits 1.7-fold (0.22 log units) above what was measured; measured number inside the range.
By their numbers in this assay, from the lowest: compound 3; then compound 2; then compound 1.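

In this assay, going from methyl to ethyl on the sulfonamide nitrogen gives a 2.1-fold lower number from compound 2 to compound 3 (0.31 log units; beyond the scatter), so even one added carbon at this place moves the number, though only modestly and just past the usual scatter. The whole change from methylamino to cyclopentyl(ethyl)amino on the sulfonyl sulfur gives a 54-fold lower number from compound 1 to compound 3 (1.73 log units; beyond the scatter), and the smaller ethyl step adds to the much larger cyclopentyl step rather than cancelling any of it. Nothing measured here accounts for either step.

Going by these compounds, it remains open whether the number keeps falling with a longer chain such as propyl or butyl, or whether ethyl is already the end of the gain. Also open, on these data alone, is whether a chain ending in a hydroxyl or an amine would fit here as well, and whether the ethyl gain would survive if cyclohexyl replaced cyclopentyl.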